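Chain length and metabolic stability in a carbamate series

The compounds below may be only part of what the source reports. "The series", "measured", "known", "first", "only" and "open" are said of these compounds alone.

Measured compounds:
compound 1 `CCCCCCCCNC(=O)Oc1ccc(Cl)cc1C(=O)Nc1cccc(Cl)c1`: 43 h
compound 2 `CCCCCCCCCCNC(=O)Oc1ccc(Cl)cc1C(=O)Nc1cccc(Cl)c1`: 43 h
compound 3 `CCCNC(=O)Oc1ccc(Cl)cc1C(=O)Nc1ccc(Cl)c(Cl)c1`: 43 h

In an ADME assay for metabolic stability, read by HPLC, at pH 7.4 (on this read-out lower numbers stand for a shorter-lived compound and higher numbers for a longer-lived compound), compound 1 gives 43 h. Compound 2 carries ethyl in place of hydrogen on a saturated chain carbon, eight bonds along the chain from an amide-type nitrogen; in this assay compound 2 gives 43 h, a step of no change at the digits printed from compound 1 to compound 2 (within the scatter). Compound 3 rests on a different core; how its core differs from that of compound 1 is not broken down here. In this assay compound 3 gives 43 h, which is level with compounds 1 and 2.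

Compound 4 `CCCCCNC(=O)Oc1ccc(Cl)cc1C(=O)Nc1ccc(Cl)c(Cl)c1` is not yet measured. It carries ethyl in place of hydrogen on a saturated chain carbon, three bonds along the chain from an amide-type nitrogen. This is the same kind of change as that from compound 1 to compound 2, though the place differs: three bonds along the chain from an amide-type nitrogen in compound 4, eight bonds along the chain in compound 2.

From compound 3 to compound 4 the expected step is no change at the digits printed from compound 3 to compound 4 (within the scatter), resting on the step of no change at the digits printed from compound 1 to compound 2 (within the scatter), where lengthening the chain left the read-out unchanged, and on all three measured values lying level. Compound 4 is estimated at 43 h, with a range from 25 h to 75 h.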

Compound 4, half-life: 43 h
Estimate against measurement, compound 4: no gap at the digits printed, within the range that was stated.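

In this assay, the step on the second core is no change at the digits printed from compound 3 to compound 4 (within the scatter), and set beside the earlier step on the core of compound 1 it shows the change carrying over without a difference: the same change on two cores in this assay, no change at the digits printed (within the scatter) from compound 1 to compound 2 and no change at the digits printed (within the scatter) from compound 3 to compound 4, 1.0-fold (0.00 log units) apart, within the scatter of two such steps

This agreement covers only these two cores, and the two changes do not sit at the same place: three bonds along the chain from an amide-type nitrogen on the core of compound 3, eight bonds along the chain on the core of compound 1. The two steps show that adding ethyl left the read-out level in both cases, but they give no reason for it and do not show that the same would hold on any further core.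

Open, from the compounds shown here alone, is whether a chain ending in an amine or a carboxylic acid, or a chain longer than that of compound 2, would stay level in this read-out. Also open, going by these compounds, is whether a urea in place of the carbamate would leave the half-life where it stands.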